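Fluoro on the anilino ring of the shared core

The compounds below may be only part of what the source reports. "The series", "measured", "known", "first", "only" and "open" are said of these compounds alone.

Measured compounds in a functional assay on MDA-MB-231 cells (Homo sapiens) for inhibition, read by MTT assay, with a stated time of 72 h; on this read-out lower numbers stand for stronger inhibition and higher numbers for weaker inhibition:
compound 1 `CCc1cccc(NC(=O)CSc2nc(Nc3ccccc3)c3ccccc3n2)c1` gives 12400 nM;
compound 2 `C=CC(=O)Nc1cccc(NC(=O)CSc2nc(Nc3ccccc3)c3ccccc3n2)c1` gives 10200 nM;
compound 3 `O=C(CSc1nc(Nc2ccccc2)c2ccccc2n1)Nc1ccc(F)c(Cl)c1` gives 21600 nM.

Compound 2 carries the lowest of the three numbers in this assay, but the gap to compound 1, a 1.2-fold lower number from compound 1 to compound 2 (0.08 log units; within the scatter), lies within the scatter, so no order between these two is claimed. Only the gap to compound 3, a 2.1-fold higher number from compound 2 to compound 3 (0.33 log units; beyond the scatter), is beyond the scatter. The step from compound 1 to compound 3, a 1.7-fold higher number from compound 1 to compound 3 (0.24 log units; within the scatter), also stays within the scatter.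

Compound 4 `C=CC(=O)Nc1cccc(NC(=O)CSc2nc(Nc3cccc(F)c3)c3ccccc3n2)c1` differs from compound 2 by fluoro in place of hydrogen on an aromatic carbon. Among the compounds with values here, none of the measured steps touches the anilino side of the core; all of them alter the aryl group on the amide-type nitrogen, and there a change to a halogenated ring, from compound 1 to compound 3, produced no step beyond the scatter. Within the data shown here, no measured step therefore bears directly on the change to compound 4, and no step beyond the scatter is expected in this assay; the expected step is a 1.1-fold lower number from compound 2 to compound 4 (0.03 log units; within the scatter). Compound 4 is estimated at 9500 nM, with a range of 4000 nM to 23000 nM.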

Compound 4, half-maximal inhibitory concentration: 8160 nM
For compound 4 the middle estimate is 1.2-fold (0.07 log units) above the measured one; low and high end bracket the measured number.
By their numbers in this assay, from the lowest: compounds 4, 2, 1 and 3 (each within the scatter of the next, the first and the last beyond it).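

Within the data shown here, the only measured change on the anilino side of the shared core, fluoro in place of hydrogen, gives in this assay a 1.3-fold lower number from compound 2 to compound 4 (0.10 log units; within the scatter) and leaves compound 4 within the scatter of compound 2. Among these compounds, the earlier steps all altered the aryl group on the amide-type nitrogen, so this is the first reading on the anilino ring, and the 3-fluorophenyl group there moves the number by no more than the scatter. No measurement at hand speaks to why this step is so small.

From the compounds shown here alone, whether a larger group on the same aromatic carbon, such as methoxy, trifluoromethyl or a dimethylamino group, would give a step beyond the scatter stays open. Also open, going by these compounds, is whether fluoro would give a similar step with the ethyl group of compound 1 in place of the vinylcarbonylamino group.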